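Methyl for methylsulfanyl on the open thiourea compound

A few compounds are considered here, and "the series" means these few. Any claim that something is new, unique, unknown or untested is made for them only; others in the source may bear on it.

In a functional assay on the whole organism (strain L.) for inhibition, with Echinochloa crus-galli as the target, with a stated time of 72 h, tested at 100 mg/L (a lower number here means less inhibition of growth, a higher number more inhibition of growth at the concentration tested), the three measured compounds gave the following:
Compound 1 `COc1cc(C)nc2n/c(=N/C(=O)c3c(-c4ccc(Cl)cc4Cl)noc3C)sn12`: 80.5%
Compound 2 `COc1cc(SC)nc(NC(=S)NC(=O)c2c(-c3ccc(Cl)cc3Cl)noc2C)n1`: 40.9%
Compound 3 `COc1cc(SC)nc2n/c(=N/C(=O)c3c(-c4ccc(Cl)cc4Cl)noc3C)sn12`: 55.6%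

Compound 2 stands lowest of the three, beyond the scatter of both compound 3 and compound 1. The unmeasured compound 4 `COc1cc(C)nc(NC(=S)NC(=O)c2c(-c3ccc(Cl)cc3Cl)noc2C)n1` differs from compound 2 by methyl in place of methylsulfanyl on an aromatic carbon, the 4-methoxy-6-(methylsulfanyl)pyrimidin-2-yl group becoming a 4-methoxy-6-methylpyrimidin-2-yl group. Among the measured compounds shown here, the one measured step that bears on this is the reverse exchange on the fused core, a number 24.9 percentage points lower from compound 1 to compound 3 (beyond the scatter). Read backwards, that step suggests a modest rise in this assay for compound 4, though on a different core. Compound 4 is therefore expected to reach about 60%, between 42% and 78%, a step of a number 19.1 percentage points higher from compound 2 to compound 4 (beyond the scatter).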

Compound 4, percent growth inhibition at one concentration: 61.8%
The estimate for compound 4 lay 1.8 percentage points below the measured number; the measured number falls inside the stated range.
By their numbers in this assay, from the lowest: compound 2; then compounds 3 and 4 (each within the scatter of the next); then compound 1.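

On the open thiourea compounds, methyl in place of methylsulfanyl on an aromatic carbon gives a number 20.9 percentage points higher from compound 2 to compound 4 (beyond the scatter) in this assay. The exchange therefore no longer rests on the fused core alone, and its size carries over between the two cores shown: the same change on two cores in this assay, a number 24.9 percentage points lower (beyond the scatter) from compound 1 to compound 3 and a number 20.9 percentage points lower (beyond the scatter) from compound 4 to compound 2, 4 percentage points apart, within the scatter of two such steps.

From the compounds shown here alone, how an amine, a chlorine atom or a longer chain at this position would read in this assay remains open on either core. The compounds shown also leave open what lies behind the size of the step.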